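The source may hold more compounds than are shown below. What is called first, only, known or untested is meant among the compounds shown, and "the series" means these compounds.

Compound 3 `CN(C)CC1CCC/C(=C\c2ccc(OC(=O)c3ccccc3)cc2)C1=O` gives 29400 nM in a functional assay on CCRF-CEM cells (Homo sapiens) (on this read-out lower numbers stand for stronger inhibition and higher numbers for weaker inhibition), the second highest of three numbers. Compound 2 `O=C1CCCC/C1=C\c1ccc(OC(=O)c2ccc(Cl)cc2)cc1` gives 41000 nM in this assay, a number within the scatter of that for compound 3. Compound 1 `CN(C)CC1CCC/C(=C\c2ccc(OC(=O)/C=C/c3ccc(F)cc3)cc2)C1=O` gives 6000 nM, and the step of a 4.9-fold higher number from compound 1 to compound 3 (0.69 log units; beyond the scatter) is beyond the scatter. Compound 4 `CN(C)CC1CCC/C(=C\c2ccc(OC(=O)c3ccc(Cl)cc3)cc2)C1=O` differs from compound 3 by chloro in place of hydrogen on an aromatic carbon. For the measured compounds named here, no measured step isolates this change; the only measured step concerns a different group on the carbonyl carbon. Compound 2 carries the same chloro group, and its number and that of compound 3 lie within the scatter of each other, though the two also differ in a second place. Compound 4 is therefore expected to show a 1.1-fold lower number from compound 3 to compound 4 (0.04 log units; within the scatter), nothing beyond the scatter, with an estimated 27000 nM and a range from 9000 nM to 80000 nM.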

Compound 4, half-maximal inhibitory concentration: 6150 nM
Estimate against measurement, compound 4: 4.4-fold (0.64 log units) above; measured number below the stated range.
By their numbers in this assay, from the lowest: compounds 1 and 4 (each within the scatter of the next); then compounds 3 and 2 (each within the scatter of the next).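

Changing phenyl to 4-chlorophenyl matters at this position: in this assay there is a clear gain (a 4.8-fold lower number from compound 3 to compound 4 (0.68 log units; beyond the scatter)). The (dimethylamino)methyl group also counts when the 4-chlorophenyl group is present (a 6.7-fold lower number from compound 2 to compound 4 (0.82 log units; beyond the scatter)), while 4-chlorophenyl and 2-(4-fluorophenyl)ethenyl cannot be told apart here (a 1.0-fold higher number from compound 1 to compound 4 (0.01 log units; within the scatter)). Nothing available explains why these steps occur. Going by these compounds, whether bromo, fluoro or methoxy at the same place would match chloro stays open. So does whether another amine, such as a morpholine, could replace the dimethylamino part.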